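The source may hold more compounds than are shown below. What is called first, only, known or untested is meant among the compounds shown, and "the series" means these compounds.

In a functional assay on M21 cells (Homo sapiens) for antiproliferative activity, read by sulforhodamine B assay, with a stated time of 48 h (on this read-out higher numbers stand for weaker inhibition and lower numbers for stronger inhibition), compound 3 `O=C1NCCN1c1ccc(S(=O)(=O)Nc2ccc(OC(F)F)cc2)cc1` gives 410 nM, within the scatter of compound 2 `O=C1NCCN1c1ccc(S(=O)(=O)Nc2ccc(F)cc2)cc1` at 230 nM. Swapping fluoro for difluoromethoxy gives a 1.8-fold higher number from compound 2 to compound 3 (0.25 log units; within the scatter). Compound 1 `O=C1NCCN1c1ccc(S(=O)(=O)Nc2ccc(C3CCCCC3)cc2)cc1` gives only a limit, > 1000 nM. Compound 4 `CCCCOc1ccc(NS(=O)(=O)c2ccc(N3CCNC3=O)cc2)cc1` carries butyl in place of difluoromethyl on an oxygen on an aromatic ring. The nearest guides are the steps away from cyclohexyl, an at least 2.4-fold lower number from compound 1 to compound 3 (0.38 log units; beyond the scatter) and an at least 4.3-fold lower number from compound 1 to compound 2 (0.63 log units; beyond the scatter), both resting on (the limit of > 1000 nM in this assay, at which 1 of the 3 values shown sits). Butyl, like cyclohexyl, is a purely carbon group, so an at least 2.4-fold lower number from compound 1 to compound 3 (0.38 log units; beyond the scatter) suggests some loss, though no measured step covers this exchange directly. The expected step is a 1.7-fold higher number from compound 3 to compound 4 (0.23 log units; within the scatter), towards weaker inhibition in this assay. Compound 4 is estimated at 700 nM, with an expected range of 200 nM to 2500 nM.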

Compound 4, half-maximal inhibitory concentration: 580 nM
The estimate for compound 4 lay 1.2-fold (0.08 log units) above the measured number; measured number inside the range.
By their numbers in this assay, from the lowest: compounds 2, 3 and 4 (each within the scatter of the next, the first and the last beyond it). At a limit, above all of these: compound 1.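

In this assay, butyl on the oxygen reads the same as difluoromethyl, so this position accepts a purely carbon chain with no fluorine: a 1.4-fold higher number from compound 3 to compound 4 (0.15 log units; within the scatter). Butoxy and fluoro on the aromatic carbon do separate, with fluoro giving the lower number: a 2.5-fold higher number from compound 2 to compound 4 (0.40 log units; beyond the scatter). The comparison with cyclohexyl, an at least 1.7-fold lower number from compound 1 to compound 4 (0.23 log units; that floor lies within the scatter), cannot be read as a real gain, and it rests on a limit: the limit of > 1000 nM in this assay, at which 1 of the 4 values shown sits.

Still open, as far as these compounds go, is whether a longer chain on the oxygen keeps this level. The effect of an amine or a carboxylic acid on the same aromatic carbon is equally unknown.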